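The compounds below may be only part of what the source reports. "The series", "measured", "known", "first", "only" and "open" are said of these compounds alone.

Compound 1 `COc1ccc(/C=C\C(=O)O[C@@H](C)[C@@H]2CC[C@H]([C@H](O)[C@H]3CC=CC(=O)O3)O2)cc1` is the starting point. In a functional assay on PC-3 cells (Homo sapiens) for inhibition, read by sulforhodamine B assay, with a stated time of 72 h (on this read-out higher numbers stand for weaker inhibition and lower numbers for stronger inhibition), compound 1 gives 10000 nM. Compound 2 `C[C@H](OC(=O)/C=C\c1ccc(O)cc1)[C@@H]1CC[C@H]([C@H](O)[C@H]2CC=CC(=O)O2)O1` differs from it in one place: hydrogen in place of methyl on an oxygen on an aromatic ring. In this assay compound 2 gives 8800 nM, so the change made a 1.1-fold lower number from compound 1 to compound 2 (0.06 log units; within the scatter). Compound 3 `COc1ccc(/C=C/C(=O)O[C@@H](C)[C@@H]2CC[C@H]([C@H](O)[C@H]3CC=CC(=O)O3)O2)cc1` shares every atom and bond with compound 1; the two cores differ only in that (the two compounds have the same atoms and bonds and differ only in configuration as drawn: 1 of 6 stereo elements differ; a double bond is drawn Z in compound 1 and E in compound 3). In this assay compound 3 gives 7500 nM. The step of a 1.3-fold lower number from compound 1 to compound 3 (0.12 log units; within the scatter) is small, and since the fact that compounds 1 and 3 differ only in the configuration as drawn nothing else separates the two.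

Compound 4 `C[C@H](OC(=O)/C=C/c1ccc(O)cc1)[C@@H]1CC[C@H]([C@H](O)[C@H]2CC=CC(=O)O2)O1` has not yet been measured. It stands to compound 3 exactly as compound 2 stands to compound 1: hydrogen in place of methyl on an oxygen on an aromatic ring. The surroundings of the changed oxygen read the same word for word in both pairs, so this is the same change made on a core that differs only in the drawn configuration of one double bond. Because the earlier step of a 1.1-fold lower number from compound 1 to compound 2 (0.06 log units; within the scatter) stayed within the scatter, the step from compound 3 to compound 4 is expected to be about as small, a 1.1-fold lower number from compound 3 to compound 4 (0.03 log units; within the scatter). Compound 4 is therefore estimated to give about 7000 nM in this assay, expected to fall between 3500 nM and 14000 nM.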

Compound 4, half-maximal inhibitory concentration: > 10000 nM
Compound 4: no number, only a limit; the forecaster's own chance of this, stated with the estimate: 20%; at least 1.4-fold (0.15 log units) between middle value and limit.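

In this assay compound 4 gives > 10000 nM, which is a limit of the assay and not a number. Replacing methoxy with hydroxy on the core with the E double bond gives an at least 1.3-fold higher number from compound 3 to compound 4 (0.12 log units; that floor lies within the scatter), and going from the Z to the E double bond among the hydroxy compounds gives an at least 1.1-fold higher number from compound 2 to compound 4 (0.05 log units; that floor lies within the scatter), so both steps are known only as floors, and those floors lie within the scatter. Set beside the step on the core of compound 1, this result shows neither that the change carries over to the second core unaltered nor that it behaves differently there: the same change on two cores in this assay, a 1.1-fold lower number (0.06 log units; within the scatter) from compound 1 to compound 2 and an at least 1.3-fold higher number (0.12 log units; that floor lies within the scatter) from compound 3 to compound 4; the limit leaves it open whether they differ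

The compounds shown carry only methoxy or hydroxy at this place on the aromatic ring, so they leave open what an ethoxy group, an amine or a carboxylic acid there would do on either core. They also leave open how far the true value of compound 4 lies from the limit, and with it the full size of both new steps.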